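Pyridinyloxy in Place of Imidazolylsulfanyl on the Shared Core

A few compounds are considered here, and "the series" means these few. Any claim that something is new, unique, unknown or untested is made for them only; others in the source may bear on it.

Three compounds share one core and differ only in the group attached to a saturated chain carbon bound to a carbonyl carbon. Compound 1 `COC(=O)c1cc(OCC(=O)[C@H](CC(=O)O)NC(=O)[C@@H](NC(=O)COc2cccc3ccccc23)C(C)C)no1` carries a (5-(methoxycarbonyl)-1,2-oxazol-3-yl)oxy group there; in a functional assay on Jurkat cells (Homo sapiens) for inhibition (on this read-out higher numbers stand for weaker inhibition and lower numbers for stronger inhibition), compound 1 gives 71000 nM. Compound 2 `CC(C)[C@H](NC(=O)COc1cccc2ccccc12)C(=O)N[C@@H](CC(=O)O)C(=O)CSc1ncc[nH]1` carries a (1H-imidazol-2-yl)sulfanyl group instead. For compound 2 this assay reports only the limit > 200000 nM, not a number. Compound 3 `CC(C)[C@H](NC(=O)COc1cccc2ccccc12)C(=O)N[C@@H](CC(=O)O)C(=O)CSc1nc2ccccc2o1` carries a (1,3-benzoxazol-2-yl)sulfanyl group. For compound 3 this assay likewise reports only the limit > 200000 nM. Both sit at the limit of > 200000 nM in this assay, at which 2 of the 3 values shown sit. Thus an at least 2.8-fold higher number from compound 1 to compound 2 (0.44 log units; beyond the scatter) and an at least 2.8-fold higher number from compound 1 to compound 3 (0.44 log units; beyond the scatter), whereas a step that the two limits leave unreadable from compound 2 to compound 3.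

Compound 4 `CC(C)[C@H](NC(=O)COc1cccc2ccccc12)C(=O)N[C@@H](CC(=O)O)C(=O)COc1ccccn1` is not yet measured. Its change from compound 2 is (pyridin-2-yl)oxy in place of (1H-imidazol-2-yl)sulfanyl on a saturated chain carbon bound to a carbonyl carbon. For the measured compounds named here, compound 1, the only compound with a number, also bears a ring joined through an oxy link, and the step of an at least 2.8-fold higher number from compound 1 to compound 2 (0.44 log units; beyond the scatter) went the other way when that oxy-linked ring gave way to a sulfanyl-linked one. Compound 4 is therefore expected to move back from the limit, an expected step of an at least 2.0-fold lower number from compound 2 to compound 4 (0.30 log units; that floor lies within the scatter). Compound 4 is estimated at 100000 nM, between 30000 nM and 300000 nM, with a real chance that only a limit is reported.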

Compound 4, half-maximal inhibitory concentration: > 200000 nM
Compound 4: no number, only a limit; the forecaster's own chance of this, stated with the estimate: 45%; middle value at least 2.0-fold (0.30 log units) away from the limit.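

Compound 4 gives only a limit, the same limit that compound 2 and compound 3 give: the limit of > 200000 nM in this assay, at which 3 of the 4 values shown sit. The steps among these three compounds therefore cannot be read. The new information lies in the comparison with compound 1: with the oxygen link kept, pyridin-2-yl in place of 5-(methoxycarbonyl)-1,2-oxazol-3-yl gives an at least 2.8-fold higher number from compound 1 to compound 4 (0.44 log units; beyond the scatter) in this assay, so an oxy-linked ring at this position does not by itself give a measurable value.

For the compounds shown here, compound 1 remains the only compound here with a number, so it stays open whether its methoxycarbonyl group or its 1,2-oxazole ring matters more. A pyridin-2-yl ring carrying a methoxycarbonyl group, a carboxylic acid or an amine would help to separate the two.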